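From 4-hydroxycyclohexyl to 2-(oxan-4-yl)ethyl on the nitrogen

This account rests on a few compounds, and the source may have more. Where it says the series, first, only, none or still open, it means among the compounds named here.

Values measured so far in an ADME assay on S9 fraction from liver (Rattus norvegicus) for metabolic stability, with a stated time of 1 h (a lower number here means that less of the compound is left, a higher number that more of the compound is left), for three compounds:
- compound 1 `N#Cc1cnc(NCc2cnccc2C(F)(F)F)cc1N[C@H]1CC[C@@H](O)CC1` gives 6%
- compound 2 `N#Cc1cnc(NCc2cnccc2C(F)(F)F)cc1NC[C@H]1CC[C@H](O)CC1` gives 6%
- compound 3 `CO[C@H]1CC[C@@H](CNc2cc(NCc3cnccc3C(F)(F)F)ncc2C#N)CC1` gives 2%

Compound 1 is level with compound 2 at the digits shown, and compound 3 lies within the usual scatter of both, so no compound in this small set stands apart. All three numbers sit low on the scale, meaning little of each compound is left at the end of the test.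

Compound 4 `N#Cc1cnc(NCc2cnccc2C(F)(F)F)cc1NCCC1CCOCC1` has not yet been measured. Its difference from compound 1 is 2-(oxan-4-yl)ethyl in place of 4-hydroxycyclohexyl on a nitrogen on an aromatic ring and, in words, 2-(oxan-4-yl)ethyl stands in place of 4-hydroxycyclohexyl on a nitrogen on an aromatic ring.

Going by the values given here, three measured steps concern this same place: no change at the digits printed from compound 1 to compound 2 (within the scatter) and a number 4 percentage points lower from compound 1 to compound 3 (within the scatter) and a number 4 percentage points lower from compound 2 to compound 3 (within the scatter) are all within the scatter. None of these compounds carries 2-(oxan-4-yl)ethyl, so this evidence is only indirect. With compound 1 at 6% as the starting point and compound 3 at 2% within the scatter of it, no step beyond the scatter is expected in this assay for this change. The expected step is a number 1 percentage points higher from compound 1 to compound 4 (within the scatter) and it is only an estimate. For compound 4 the estimated value is 7% with an expected range from 1% to 25% for the measurement.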

Compound 4, percent of the compound remaining: 0%
Estimate against measurement, compound 4: 7 percentage points above, outside the stated range (below it).
By their numbers in this assay, from the lowest: compounds 4, 3, 1 and 2 (each within the scatter of the next).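

In this assay this place on a nitrogen on an aromatic ring now also holds a longer group, with its ring containing 1 hetero atom and with 0 hydrogen-bond donors, and the comparisons read a number 6 percentage points lower from compound 1 to compound 4 (within the scatter) and a number 6 percentage points lower from compound 2 to compound 4 (within the scatter) and a number 2 percentage points lower from compound 3 to compound 4 (within the scatter). Replacing 4-hydroxycyclohexyl, with its carbon-only ring and 1 hydrogen-bond donor, by 2-(oxan-4-yl)ethyl therefore gives no step beyond the scatter, so compound 4 joins the other three compounds at the low end of the scale. No measurement shown here explains the low numbers of these four compounds.

The compounds shown leave open whether a quite different group at this nitrogen, such as an amine or a carboxylic acid, would leave more of the compound at the end of the test. They also leave open whether any of the four groups tested differ from one another at all, since all four numbers lie within the scatter of the next and close to the bottom of the scale.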